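The compounds below may be only part of what the source reports. "The series", "measured", "known", "first", "only" and "open" are said of these compounds alone.

Measured compounds in the series:
- compound 1, `O=C(c1ccccc1)N1CCC(NS(=O)(=O)c2cc(S(=O)(=O)c3ccccc3)ccc2C(F)(F)F)CC1`: 70 nM
- compound 2, `O=C(c1ccccn1)N1CCC(NS(=O)(=O)c2cc(S(=O)(=O)c3ccccc3)ccc2C(F)(F)F)CC1`: 60 nM
- compound 3, `O=C(O)CCCC(=O)N1CCC(NS(=O)(=O)c2cc(S(=O)(=O)c3ccccc3)ccc2C(F)(F)F)CC1`: 500 nM

All three numbers come from an assay on isolated protein for displacement of a labelled ligand from secreted frizzled-related protein 1 (Homo sapiens), read by fluorescence polarization, with a stated time of 30 min; a higher number here means a weaker inhibitor, a lower number a stronger inhibitor. Compound 2 gives the lowest of the three numbers, but compound 1 sits within the scatter of it, so the two cannot be placed in order: a 1.2-fold lower number from compound 1 to compound 2 (0.07 log units; within the scatter). Compound 3 stands apart, with a 7.1-fold higher number from compound 1 to compound 3 (0.85 log units; beyond the scatter) and an 8.3-fold higher number from compound 2 to compound 3 (0.92 log units; beyond the scatter).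

The next compound, compound 4, is `O=C(C1CCNCC1)N1CCC(NS(=O)(=O)c2cc(S(=O)(=O)c3ccccc3)ccc2C(F)(F)F)CC1`. Its difference from compound 2 is piperidin-4-yl in place of pyridin-2-yl on a carbonyl carbon. The change is on the same carbonyl carbon that the measured steps probe. Among the measured compounds shown here, the one step that leaves the aromatic group there, to 3-carboxypropyl, cost a modest amount; the step between phenyl and pyridin-2-yl cost nothing beyond the scatter. Piperidin-4-yl, a non-aromatic ring carrying a hydrogen-bond donor, lies between these cases, and a loss smaller than that seen for compound 3 is expected, though beyond the scatter.

Compound 4 is therefore estimated at 200 nM, with a range of 80 nM to 600 nM, meaning an expected step of a 3.3-fold higher number from compound 2 to compound 4 (0.52 log units; beyond the scatter).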

Compound 4, half-maximal inhibitory concentration: 120 nM
Estimate against measurement, compound 4: 1.7-fold (0.22 log units) above; the range from low to high includes it.
By their numbers in this assay, from the lowest: compounds 2, 1 and 4 (each within the scatter of the next); then compound 3.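

In this assay, an aromatic ring on this carbonyl carbon is not shown to be needed: the non-aromatic piperidin-4-yl gives steps within the scatter against both aromatic groups (a 2.0-fold higher number from compound 2 to compound 4 (0.30 log units; within the scatter); a 1.7-fold higher number from compound 1 to compound 4 (0.23 log units; within the scatter)). The loss seen with 3-carboxypropyl therefore does not extend to every non-aromatic group at this position, and piperidin-4-yl recovers a measurable part of it (a 4.2-fold lower number from compound 3 to compound 4 (0.62 log units; beyond the scatter)). Nothing shown here bears on why these groups differ.

The compounds shown leave open whether the ring nitrogen of piperidin-4-yl contributes at all, a question that cyclohexyl or tetrahydropyran-4-yl at the same carbonyl carbon would address, as would an N-methyl or N-acetyl group on that nitrogen. They also leave open whether the higher number of compound 3 belongs to the carboxylic acid or to the open chain, which a methyl ester or a plain butyl chain in place of 3-carboxypropyl would separate.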